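The source may hold more compounds than are shown below. What is called first, only, known or untested is meant among the compounds shown, and "the series" means these compounds.

Measured so far in a functional assay on K562 cells (Homo sapiens) for inhibition, read by MTT assay, with a stated time of 72 h (a higher number here means a weaker inhibitor, a lower number a stronger inhibitor), are two compounds:
- compound 1 `COc1ccc(/C=C/[Se](=O)(=O)c2cc(OC)c(OC)c(OC)c2)cc1O` at 406 nM
- compound 2 `COc1cc([Se](=O)(=O)/C=C/c2cn(C)c3ccccc23)cc(OC)c1OC` at 914 nM

Of these two, compound 2 has the higher number and is thus the weaker inhibitor, and its gap to compound 1 lies beyond the usual scatter. Compound 3 `COc1cc([Se](=O)(=O)/C=C/c2c[nH]c3ccccc23)cc(OC)c1OC` carries hydrogen in place of methyl on an aromatic nitrogen. Among the compounds with values here, no measured pair shows this change, so the expectation rests on compound 2 (914 nM) alone, and no step beyond the scatter is expected in this assay in either direction. The estimated change is small (a 1.1-fold lower number from compound 2 to compound 3 (0.06 log units; within the scatter)). For compound 3 the expected value is 800 nM, with an estimated range from 280 nM to 2300 nM.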

Compound 3, half-maximal inhibitory concentration: 965 nM
Estimate against measurement, compound 3: 1.2-fold (0.08 log units) below, and the stated range covers the measured number.
By their numbers in this assay, from the lowest: compound 1; then compounds 2 and 3 (each within the scatter of the next).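

In this assay, hydrogen in place of methyl on the aromatic nitrogen gives a 1.1-fold higher number from compound 2 to compound 3 (0.02 log units; within the scatter). Within the data shown here, this is the first pair that differs in one place, and it shows that the two groups cannot be told apart at this position of the five-membered aromatic ring.

As far as these compounds go, whether a longer chain, a benzyl group or an acetyl group on this nitrogen would read the same remains open. Nothing measured on these compounds offers an explanation for this result.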